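From pyridin-3-yl to 1H-pyrazol-5-yl: an expected step

The source may report more compounds than this note shows. Statements on the series, on what has been measured and on what is new or still open speak of the compounds shown alone.

Measured in a functional assay on A-375 cells (Homo sapiens) for antiproliferative activity; on this read-out lower numbers stand for stronger inhibition and higher numbers for weaker inhibition:
- compound 1 `O=C(Nc1ccc(-c2cscn2)cc1)C1CCCN(Cc2cccc(F)c2F)C1`: 1480 nM
- compound 2 `O=C(Nc1ccc(-c2cscn2)cc1)C1CCCN(Cc2ccc(Cl)c(Cl)c2)C1`: 1730 nM
- compound 3 `O=C(Nc1ccc(-c2cccnc2)cc1)C1CCCN(Cc2ccc(F)c(F)c2)C1`: 610 nM

Compound 3 has the lowest number of the three, which makes it the strongest inhibitor so far. Compound 4 `O=C(Nc1ccc(-c2ccn[nH]2)cc1)C1CCCN(Cc2ccc(F)c(F)c2)C1` is unmeasured and carries 1H-pyrazol-5-yl in place of pyridin-3-yl on an aromatic carbon. For the measured compounds named here, the one measured step, a 1.2-fold higher number from compound 1 to compound 2 (0.07 log units; within the scatter), lies elsewhere in the molecule, so no measured step covers this swap alone. Compound 1, at 1480 nM, and compound 2, at 1730 nM, differ from compound 3 in two places and offer only a weak hint. A small move towards a higher number in this assay is therefore expected, with wide uncertainty. The estimated step is a 1.6-fold higher number from compound 3 to compound 4 (0.21 log units; within the scatter). For compound 4 the estimated value is 1000 nM, with an expected range of 350 nM to 2800 nM.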

Compound 4, half-maximal inhibitory concentration: 520 nM
For compound 4 the middle estimate is 1.9-fold (0.28 log units) above the measured one; measured number inside the range.
By their numbers in this assay, from the lowest: compounds 4 and 3 (each within the scatter of the next); then compounds 1 and 2 (each within the scatter of the next).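

In this assay, replacing pyridin-3-yl with 1H-pyrazol-5-yl on this aromatic carbon, para to a large group, gives a 1.2-fold lower number from compound 3 to compound 4 (0.07 log units; within the scatter). A six-membered aromatic ring with 1 hetero atom can therefore give way to a five-membered aromatic ring with 2 hetero atoms and 1 hydrogen-bond donor, with the two numbers staying within the usual scatter. No supporting measurement explains this result.

The compounds shown leave open how a non-ring group, such as an amine or a carboxylic acid, would read at this position.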